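The compounds below may be only part of what the source reports. "The series", "measured", "known", "first", "only" and "open" are said of these compounds alone.

Of the compounds shown here, two have been measured in a physicochemical assay for lipophilicity, in phosphate buffer, measured as octanol-water partition, with a stated time of 24 h (a higher number here means a more lipophilic compound, a lower number a more polar compound), so far. Compound 1 `Cc1cc(Oc2ccc(/C=N/Nc3nc4ccccc4s3)cc2)ccc1Cl` gives 5.5, the higher of the two numbers. Compound 2 `O=C(CSc1nc2ccccc2s1)N/N=C1\C(=O)Nc2ccccc21` gives 3.2, and the gap between compound 2 and compound 1 lies beyond the scatter. Compound 3 `Cc1ccc(Oc2ccc(/C=N/Nc3nc4ccccc4s3)cc2)cc1` is not yet measured. It differs from compound 1 in one place: 4-methylphenyl in place of 4-chloro-3-methylphenyl on an oxygen on an aromatic ring. Going by the values given here, no step between two measured compounds covers this change, so the expectation rests on the structural difference alone. The step from compound 1 to compound 3 is expected to run downward and beyond the scatter, about a number 0.70 log units lower from compound 1 to compound 3 (beyond the scatter). Compound 3 is estimated at 4.8 in this assay, with a range from 4.3 to 5.3.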

Compound 3, partition coefficient: 5.4
Beside the measured number, compound 3's estimate is 0.60 log units below it; measured number above the stated range.
By their numbers in this assay, from the lowest: compound 2; then compounds 3 and 1 (each within the scatter of the next).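

Going by these compounds alone, the first one-place step falls on an oxygen on an aromatic ring: in this assay, 4-methylphenyl in place of 4-chloro-3-methylphenyl gives a number 0.10 log units lower from compound 1 to compound 3 (within the scatter). At this position, this exchange therefore leaves the read-out unresolved from the earlier number. Nothing on hand offers an explanation for the size of this step.

As far as these compounds go, how the read-out responds to a carboxylic acid or an amine in place of 4-methylphenyl remains open. The other places on the core of compound 1 still lack any one-place step.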